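The compounds below may be only part of what the source reports. "The series", "measured", "known", "first", "only" and "open" are said of these compounds alone.

Compound 1 `CCCSc1nc(N/N=C/c2ccc(Br)cc2)c2nnn(Cc3ccccc3)c2n1`: 34900 nM
Compound 2 `CCCSc1nc(N/N=C(\C)c2ccccc2)c2nnn(Cc3ccccc3)c2n1`: 25400 nM

Both compounds were measured in a functional assay on MGC-803 cells (Homo sapiens) for antiproliferative activity, read by MTT assay, with a stated time of 72 h; a higher number here means a weaker inhibitor, a lower number a stronger inhibitor. Compound 2, at 25400 nM, stands within the scatter of compound 1, so these two numbers set neither compound ahead of the other. Compound 3 `CCCSc1nc(N/N=C(\C)c2ccc(Br)cc2)c2nnn(Cc3ccccc3)c2n1` is compound 2 with a single change, bromo in place of hydrogen on an aromatic carbon, which turns phenyl into 4-bromophenyl.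

Within the data shown here, only one measured step bears on this change, a 1.4-fold lower number from compound 1 to compound 2 (0.14 log units; within the scatter). That step also runs between 4-bromophenyl and phenyl, but it differs in a methyl group as well, so it does not isolate the bromo. Among the measured compounds shown here, it is small and lies within the scatter, and it is the only guide available. No shift beyond the scatter is therefore expected in this assay. The expected result is a 1.1-fold higher number from compound 2 to compound 3 (0.04 log units; within the scatter), which would stay within the scatter. For compound 3 the estimated value is 28000 nM, with an expected range of 14000 nM to 55000 nM.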

Compound 3, half-maximal inhibitory concentration: 6020 nM
The estimate for compound 3 lay 4.7-fold (0.67 log units) above the measured number; the whole stated range lies above it.
By their numbers in this assay, from the lowest: compound 3; then compounds 2 and 1 (each within the scatter of the next).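

In this assay, bromo in place of hydrogen on an aromatic carbon, para to a large group, gives a 4.2-fold lower number from compound 2 to compound 3 (0.63 log units; beyond the scatter) and so isolates the bromo in a single change, which the earlier pair could not do; with 4-bromophenyl present in both compounds, the larger group on the nitrogen gives a 5.8-fold lower number from compound 1 to compound 3 (0.76 log units; beyond the scatter) as well. Compound 1, with bromo but without the methyl group, and compound 2, with the methyl group but without bromo, stay within the scatter of each other, and only compound 3, which carries both, stands apart from them. The bromo therefore matters at this position in the presence of the methyl group, while nothing given here accounts for that finding.

From the compounds shown here alone, whether the step is particular to bromo remains open, since a chloro, a methoxy or an amine at the same ring carbon could give a different number. Going by these compounds, it is equally open whether an ethyl chain in place of the methyl group would keep the gain, and whether bromo on another carbon of the ring would produce it at all.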